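The compounds below may be only part of what the source reports. "The series", "measured", "known", "first", "only" and "open" are said of these compounds alone.

Series notes, exposure in an in vivo ADME assay on the whole organism (plasma) for pharmacokinetics, with Canis familiaris (Canis lupus familiaris) as the target, at a dose of 1 mg/kg by the oral route; on this read-out higher numbers stand for higher exposure at the dose given and lower numbers for lower exposure.

Of the compounds shown here, three carry numbers so far. Compound 1 `Cc1cnc(NCC2(c3ccccc3)CCC2)c(=O)n1CC(=O)NCc1ccc2c(N)noc2c1` gives 1310 nM in this assay. Compound 2 `Cc1cnc(NCC2(c3ccc(F)cc3)CC2)c(=O)n1CC(=O)NCc1ccc2c(N)noc2c1` gives 1780 nM. Compound 3 `Cc1ccc(NS(=O)(=O)Cc2ccccc2)c(=O)n1CC(=O)NCc1ccc2onc(N)c2c1`, with a different arrangement on the shared core, gives 498 nM. For the measured compounds named here, the one step between neighbours that differ in a single place is a 1.4-fold higher number from compound 1 to compound 2 (0.13 log units; within the scatter), so the two compounds sit within the scatter of each other. Compound 2 stands at the top of the three numbers, with compound 1 within the scatter of it and compound 3 well beyond it, lower.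

Compound 4 `Cc1cnc(NCC2(c3ccc(F)cc3)CC2)c(=O)n1CC(=O)NCc1ccc2[nH]nc(N)c2c1` is not yet measured. Relative to compound 2 the change is a group of 10 heavy atoms (7 carbon, 3 nitrogen; one five-membered aromatic ring with 2 hetero atoms, one six-membered aromatic ring of carbon only) in place of a group of 10 heavy atoms (7 carbon, 2 nitrogen, 1 oxygen; one five-membered aromatic ring with 2 hetero atoms, one six-membered aromatic ring of carbon only), on a saturated chain carbon bound to an amide-type nitrogen. Going by the values given here, no measured step touches this part of the molecule: the only step in hand, from compound 1 to compound 2, alters the group on the other end, and compound 3 differs from the rest in several places at once. Among the compounds with values here, there is therefore no precedent from which a direction can be read. In the absence of one, the expectation for this assay is a step of about a 1.5-fold lower number from compound 2 to compound 4 (0.17 log units; within the scatter), with wide uncertainty on either side. Compound 4 is thus estimated at 1200 nM, within a range of 400 nM to 3600 nM.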

Compound 4, maximal plasma concentration in the Canis familiaris assay: 1850 nM
For compound 4 the middle estimate is 1.5-fold (0.19 log units) below the measured one, and the stated range covers the measured number.
By their numbers in the Canis familiaris assay, from the lowest: compound 3; then compounds 1, 2 and 4 (each within the scatter of the next).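

For the compounds shown here, in the Canis familiaris assay, 3-amino-1H-indazol-5-yl on a saturated chain carbon bound to an amide-type nitrogen gives a 1.0-fold higher number from compound 2 to compound 4 (0.02 log units; within the scatter), the first reading at this end of the molecule, and it shows that this exchange of one group of 10 heavy atoms for another leaves the two numbers within the scatter of each other. In a physicochemical assay for acid dissociation, compound 2 gives 8.6 and compound 4 gives 3.6, so the two compounds that cannot be told apart on exposure stand far apart on this second read-out. A shift of this size in the physicochemical assay therefore came with no step beyond the scatter in the Canis familiaris assay: the measured acid dissociation constant of compound 2, 8.6, and of compound 4, 3.6, a number 5.00 log units lower (beyond the scatter).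

From the compounds shown here alone, this rests on a single pair, and it remains open whether a carboxylic acid or an aliphatic amine in place of the 3-amino-1H-indazol-5-yl group would also leave exposure within the scatter. Going by these compounds, it is equally open whether the same exchange would read alike with 1-phenylcyclobutyl in place of 1-(4-fluorophenyl)cyclopropyl at the other end of the molecule.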